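Carbamoyl Gives Way to 1H-1,2,4-Triazol-1-yl

This account rests on a few compounds, and the source may have more. Where it says the series, first, only, none or still open, it means among the compounds named here.

In an ADME assay on S9 fraction from liver (Rattus norvegicus) for metabolic stability, with a stated time of 1 h (a higher number here means that more of the compound is left, a lower number that less of the compound is left), compound 3 `N#Cc1cnc(NCc2cnccc2C(F)(F)F)cc1N[C@H]1CC[C@@H](C(N)=O)CC1` gives 30%. Compound 1 `N#Cc1cnc(NCc2cnccc2C(F)(F)F)cc1N[C@H]1CC[C@H](O)CC1` gives 25%, so the two stand level within the scatter, while compound 2 `N#Cc1cnc(NCc2cnccc2C(F)(F)F)cc1NCCC1CCOCC1` gives 0%, clearly apart from both. Compound 4 `N#Cc1cnc(NCc2cnccc2C(F)(F)F)cc1N[C@H]1CC[C@@H](n2cncn2)CC1` keeps the shared core and changes one group: 1H-1,2,4-triazol-1-yl in place of carbamoyl on a saturated ring carbon. In short, it carries 1H-1,2,4-triazol-1-yl in place of carbamoyl on a saturated ring carbon. Among the compounds with values here, no measured step makes this exact exchange. The closest evidence is 4-carbamoylcyclohexyl in place of 4-hydroxycyclohexyl, which gives a number 5 percentage points higher from compound 1 to compound 3 (within the scatter). The two larger steps, a number 25 percentage points lower from compound 1 to compound 2 (beyond the scatter) and a number 30 percentage points higher from compound 2 to compound 3 (beyond the scatter), both involve 2-(oxan-4-yl)ethyl, a group compound 4 does not carry. Within the data shown here, with only this thin evidence, no step beyond the scatter is expected. The expected change is a number 5 percentage points lower from compound 3 to compound 4 (within the scatter). For compound 4 the estimated value is 25%, with an expected range of 5% to 45%.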

Compound 4, percent of the compound remaining: 44%
Compound 4: middle estimate off by 19 percentage points, on the low side; low and high end bracket the measured number.
By their numbers in this assay, from the lowest: compound 2; then compounds 1 and 3 (each within the scatter of the next); then compound 4.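

In this assay, the saturated ring carbon of the six-membered non-aromatic ring now shows that an exchange here can move the read-out: 1H-1,2,4-triazol-1-yl in place of carbamoyl gives a number 14 percentage points higher from compound 3 to compound 4 (beyond the scatter), whereas 4-carbamoylcyclohexyl in place of 4-hydroxycyclohexyl gave a number 5 percentage points higher from compound 1 to compound 3 (within the scatter) and stayed inside the scatter. The change also shows that this carbon can carry a five-membered aromatic ring with 3 hetero atoms and 0 hydrogen-bond donors without any loss in the amount of compound left. Nothing measured here accounts for this rise.

Going by these compounds, whether the rise belongs to this particular group or would come with any five-membered aromatic ring remains open, and how a pyrazole, an imidazole, an amine or a carboxylic acid on this carbon would compare cannot be told. The compounds shown also leave open how 1H-1,2,4-triazol-1-yl would read with the opposite arrangement on the ring.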